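Swapping a Furan for a Methylpyrazole on the Phenyl Ring

The source may hold more compounds than are shown below. What is called first, only, known or untested is meant among the compounds shown, and "the series" means these compounds.

Within the data shown here, in a functional assay for activation of Alpha-1D adrenergic receptor (Homo sapiens), read by calcium flux (on this read-out lower numbers stand for an effect already at smaller amounts and higher numbers for an effect only at larger amounts of compound), compound 2 `c1ccc(-c2ccoc2)c(OCC2=NCCN2)c1` gives 5.01 nM, the only full number in this small set. Compound 1 `Cc1cccnc1-c1ccccc1OCC1=NCCN1` reaches only a limit of this assay, < 100000 nM, as the entry the limit of < 100000 nM in this assay, at which 1 of the 2 values shown sits, records. Compound 3 `Cn1nccc1-c1ccccc1OCC1=NCCN1` has not been measured yet; it differs from compound 2 by 1-methyl-1H-pyrazol-5-yl in place of furan-3-yl on an aromatic carbon. Among the measured compounds shown here, no step between two measured compounds is available, so the size of this change can only be estimated. The step of an 8.0-fold higher number from compound 2 to compound 3 (0.90 log units; beyond the scatter) is expected to be a modest loss, somewhat beyond the usual scatter. Compound 3 is estimated at 40 nM, within a range from 5 nM to 400 nM.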

Compound 3, half-maximal effective concentration: < 100000 nM
Compound 3 ended at the assay's limit; the forecaster's own chance of this, stated with the estimate: 10%; the middle value lies beyond the limit too.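

No size can be read for the change from compound 2 to compound 3, because compound 3 gives a limit, not a number: the limit of < 100000 nM in this assay, at which 2 of the 3 values shown sit.

Still open, from the compounds shown here alone, is how far 1-methyl-1H-pyrazol-5-yl in place of furan-3-yl really shifts the result in this assay.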